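A Methyl Cap on the Oxygen of Compound 3

A few compounds are considered here, and "the series" means these few. Any claim that something is new, unique, unknown or untested is made for them only; others in the source may bear on it.

Compound 3 `CS(=O)(=O)Nc1ccc(O)c2c1CCCC2c1c[nH]cn1` carries a hydroxy group on its aromatic ring. In an assay on isolated protein for binding affinity to Alpha-1D adrenergic receptor (Rattus norvegicus), read by radioligand binding (a lower number here means a stronger inhibitor, a higher number a weaker inhibitor), compound 3 gives only a limit, < 10000 nM, which is a boundary of the measurement rather than a number. Its chloro counterpart, compound 1 `CS(=O)(=O)Nc1ccc(Cl)c2c1CCCC2c1c[nH]cn1`, gives 2880 nM in this assay. A further relative, compound 2 `CS(=O)(=O)Nc1cccc2c1CCCCC2c1c[nH]cn1`, gives 2510 nM in this assay. The only single-point step among these, a step that the limit leaves unreadable from compound 1 to compound 3, cannot be sized because the limit of < 10000 nM in this assay, at which 1 of the 3 values shown sits, sits where compound 3 stands.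

Compound 4 `COc1ccc(NS(C)(=O)=O)c2c1C(c1c[nH]cn1)CCC2` differs from compound 3 by methyl in place of hydrogen on an oxygen on an aromatic ring. For the measured compounds named here, no measured step in this set touches an oxygen-bound hydrogen, and the one step that connects compound 3 to a measured neighbour is unreadable, so nothing here argues for a shift in either direction beyond the usual scatter. Compound 4 is therefore expected to land near the values seen for compounds 1 and 2, with an estimated 3500 nM and a range from 800 nM to 15000 nM. The step that the limit leaves unreadable from compound 3 to compound 4 that this estimate implies is expected to be small, with a real chance that this assay again reports only a limit.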

Compound 4, inhibition constant: < 10000 nM
Compound 4 ended at the assay's limit (the forecaster's own chance of this, stated with the estimate: 40%); the middle value does not contradict the limit.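

Compound 3 and compound 4 both end at a limit in this assay rather than at a number, so neither step to compound 4, from compound 3 or from compound 1, can be read, because of this boundary: the limit of < 10000 nM in this assay, at which 2 of the 4 values shown sit.

The compounds shown leave open how much, and in which direction, the methyl cap on the oxygen shifts binding.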